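A smaller sulfanyl group on compound 2

The source may hold more compounds than are shown below. What is called first, only, known or untested is meant among the compounds shown, and "the series" means these compounds.

In a functional assay on MGC-803 cells (Homo sapiens) for antiproliferative activity, read by MTT assay, with a stated time of 48 h (on this read-out higher numbers stand for weaker inhibition and lower numbers for stronger inhibition), compound 2 (`COc1ccc(CN(C(=O)CCSc2nc3ccccc3o2)c2cc(OC)c(OC)c(OC)c2)cc1`) stands at 640 nM as the lowest of three numbers. Compound 3 (`COc1ccc(CN(C(=O)CCCCSc2nc3ccccc3o2)c2cc(OC)c(OC)c(OC)c2)cc1`) reads 1360 nM and compound 1 (`COc1ccc(CN(C(=O)CSC2=CN=NC2C)c2cc(OC)c(OC)c(OC)c2)cc1`) reads 2960 nM on the same measure. Compound 4 (`COc1ccc(CN(C(=O)CSc2nncs2)c2cc(OC)c(OC)c(OC)c2)cc1`) is unmeasured and carries (1,3,4-thiadiazol-2-yl)sulfanyl in place of ((1,3-benzoxazol-2-yl)sulfanyl)methyl on a saturated chain carbon bound to a carbonyl carbon. Like compound 1, compound 4 has no six-membered ring in that group, and the exchange of group gave a 4.6-fold lower number from compound 1 to compound 2 (0.67 log units; beyond the scatter) as a modest step. A change on the chain gave a 2.1-fold higher number from compound 2 to compound 3 (0.33 log units; beyond the scatter) as a second modest step. A modest rise is therefore expected, estimated as a 2.8-fold higher number from compound 2 to compound 4 (0.45 log units; beyond the scatter) in this assay on this evidence. For compound 4 an estimated 1800 nM is expected, within 700 nM to 4500 nM on this measure.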

Compound 4, half-maximal inhibitory concentration: 1150 nM
Compound 4: middle estimate off by 1.6-fold (0.19 log units), on the high side; measured number inside the range.
By their numbers in this assay, from the lowest: compounds 2, 4 and 3 (each within the scatter of the next, the first and the last beyond it); then compound 1.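

In this assay, (1,3,4-thiadiazol-2-yl)sulfanyl in place of ((1,3-benzoxazol-2-yl)sulfanyl)methyl gave (a 1.8-fold higher number from compound 2 to compound 4 (0.25 log units; within the scatter)), so at this position the six-membered aromatic ring of carbon only could be lost without a change beyond the scatter. Among the groups without that ring, the five-membered ring on the sulfur still counted (a 2.6-fold lower number from compound 1 to compound 4 (0.41 log units; beyond the scatter)). No measurement offered here gives a cause for either step. The compounds shown leave open how an amine or a carboxylic acid on the 1,3,4-thiadiazol-2-yl ring would read, and how (1,3,4-thiadiazol-2-yl)sulfanyl would read on a longer chain.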